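This account rests on a few compounds, and the source may have more. Where it says the series, first, only, none or still open, it means among the compounds named here.

Two sugar-bearing compounds set the scene. Compound 1 `COc1cc(/C=C/C(=O)O[C@@H]2C[C@@](O)(CO)[C@H]3[C@H](O[C@@H]4O[C@H](CO)[C@@H](O)[C@H](O)[C@H]4O)OC=C[C@H]32)ccc1O` carries an aromatic ester, and in a functional assay for inhibition, read by fluorescence, with a stated time of 5 min, in the presence of a further agent that is not named here (on this read-out higher numbers stand for weaker inhibition and lower numbers for stronger inhibition), compound 1 gives 2000 nM. Compound 2 `OC[C@H]1O[C@@H](OCCc2ccc(O)cc2)[C@H](O[C@@H]2OC[C@](O)(CO)[C@H]2O)[C@@H](O)[C@@H]1O` lacks any such ester group, and in this assay compound 2 gives 15700 nM, the higher of the two numbers and so the weaker inhibitor, a gap that lies beyond the usual scatter. Compound 3 `COc1cc(C(=O)OC[C@@]2(O)CO[C@@H](O[C@H]3[C@H](OCCc4ccc(O)cc4)O[C@H](CO)[C@@H](O)[C@@H]3O)[C@@H]2O)ccc1O` is compound 2 with a single change: (4-hydroxy-3-methoxyphenyl)carbonyl in place of hydrogen on an oxygen on a saturated carbon. On this slender basis, a modest step toward stronger inhibition is expected, a 2.6-fold lower number from compound 2 to compound 3 (0.42 log units; beyond the scatter). For compound 3 the estimated value is 6000 nM, within a range from 2500 nM to 16000 nM.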

Compound 3, half-maximal inhibitory concentration: 8600 nM
Compound 3: the middle estimate sits 1.4-fold (0.16 log units) below what was measured; the measured number falls inside the stated range.
By their numbers in this assay, from the lowest: compound 1; then compounds 3 and 2 (each within the scatter of the next).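

In this assay, going by these compounds alone, putting (4-hydroxy-3-methoxyphenyl)carbonyl in place of hydrogen on an oxygen on a saturated carbon gives a 1.8-fold lower number from compound 2 to compound 3 (0.26 log units; within the scatter) and so no step that can be told apart from repeat scatter. At this position, then, a group of this size is tolerated, but it brings no clear gain in inhibition. Nothing available bears on why this is so.

As far as these compounds go, it remains open whether an acetyl group or a longer chain ending in a carboxylic acid or an amine on this oxygen would move the number beyond the scatter.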